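The source may hold more compounds than are shown below. What is called first, only, known or untested is meant among the compounds shown, and "the series" means these compounds.

Of the compounds shown here, two that share one core have so far been measured in an assay on CHO cells for displacement of a labelled ligand from adenosine receptor A1 (Homo sapiens), read by scintillation counting, with a stated time of 1 h, tested at 1 uM; a higher number here means more inhibition at the concentration tested (going by the name of the read-out), a lower number less inhibition. Compound 1 `Nc1ncc(-c2ccc(OCc3ccccc3)c(Cl)c2)c(-c2ccccc2)n1` gives 38% in this assay. Compound 2 `O=C(Nc1ncc(-c2cccc(Cl)c2)c(-c2ccccc2)n1)C1CCC1` gives 52% in this assay, the higher of the two numbers, and its distance from compound 1 lies beyond the usual scatter of such measurements. The next compound, compound 3 `CC(C)CCNc1ncc(-c2cccc(Cl)c2)c(-c2ccccc2)n1`, has not yet been measured in this assay. It differs from compound 2 in a single place: isopentyl in place of cyclobutylcarbonyl on a nitrogen on an aromatic ring. Seen one bond further out, the (cyclobutylcarbonyl)amino group of compound 2 becomes an isopentylamino group in compound 3. For the measured compounds named here, no pair of measured compounds shows what this kind of change does in this assay, so the size of the step can only be judged from the single value of compound 2. A modest fall, near the edge of the scatter, seems the most likely outcome, though a small rise cannot be excluded. Compound 3 is therefore expected to show 45% in this assay, within a range from 20% to 70%. The step this estimate implies, a number 7 percentage points lower from compound 2 to compound 3 (within the scatter), is expected to be small.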

Compound 3, a percentage reported as inhibition, at one concentration (the size of the read-out at that concentration, not a potency): 39%
The estimate for compound 3 lay 6 percentage points above the measured number; the range from low to high includes it.
By their numbers in this assay, from the lowest: compounds 1 and 3 (each within the scatter of the next); then compound 2.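

For the compounds shown here, this is the only measured step at this place, a nitrogen on an aromatic ring, and it shows that the group held there affects the result: in this assay, isopentyl in place of cyclobutylcarbonyl gives a number 13 percentage points lower from compound 2 to compound 3 (beyond the scatter) and so moves the number beyond the usual scatter. The change replaces a group with a ring and a carbonyl by an open carbon chain with neither, and compound 3 still gives 39% without either feature. No measurement shown explains the step, and this single pair cannot tell which of these differences matters.

Still open, going by these compounds, is whether the ring, the carbonyl or the shape of the chain accounts for the step, a question that an acetyl group, a cyclobutyl group joined directly to the nitrogen, or a longer chain at the same place could help to separate. On these data alone, compound 1 differs from compound 2 and from compound 3 in more than one place, so whether this change would act in the same way with a benzyloxy group on the chlorophenyl ring also remains unknown.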